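This account rests on a few compounds, and the source may have more. Where it says the series, first, only, none or still open, it means among the compounds named here.

Series notes. Compound 1 `CCCCCCNC(=O)n1cc(F)c(=O)n(C)c1=O` carries a methyl on the aromatic nitrogen of the shared core and in an assay on HEK293 cells for inhibition of acid ceramidase (Rattus norvegicus), read by LC-MS, with a stated time of 30 min (a lower number here means a stronger inhibitor, a higher number a weaker inhibitor), compound 1 gives 13 nM. Compound 2 `CCCCCCNC(=O)n1cc(F)c(=O)n(C(=O)C(C)C)c1=O` carries an isopropylcarbonyl at that position instead, and in this assay compound 2 gives 21 nM. Within the data shown here, the only step measured so far, a 1.6-fold higher number from compound 1 to compound 2 (0.21 log units; within the scatter), is within the scatter. On the two numbers shown, compound 2 stands highest, with compound 1 nearest, and the two cannot be told apart.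

Compound 3 `CCCCCCNC(=O)n1cc(F)c(=O)n(C(=O)OC)c1=O` is the next analogue: methoxy in place of isopropyl on a carbonyl carbon, so the isopropylcarbonyl becomes a methoxycarbonyl. Among the measured compounds shown here, no measured step varies the group on this carbonyl carbon; the step from compound 1 to compound 2 bears only indirectly, in that exchanging the methyl for the whole isopropylcarbonyl left the number within the scatter in this assay. A change confined to the outer part of that same acyl group is therefore expected to move the number little, with no direction preferred beyond the scatter, as a 1.1-fold lower number from compound 2 to compound 3 (0.02 log units; within the scatter). For compound 3 the value in this assay is estimated at 20 nM, within 8 nM to 50 nM.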

Compound 3, half-maximal inhibitory concentration: 7 nM
For compound 3 the middle estimate is 2.9-fold (0.46 log units) above the measured one; the whole stated range lies above it.
By their numbers in this assay, from the lowest: compounds 3, 1 and 2 (each within the scatter of the next, the first and the last beyond it).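

In this assay, among these compounds, the group on the carbonyl carbon is the first place where a single exchange reaches beyond the scatter: a 3.0-fold lower number from compound 2 to compound 3 (0.48 log units; beyond the scatter), with methoxy in place of isopropyl, is a modest step. The exchange on the aromatic nitrogen does not reach that far, since a 1.9-fold lower number from compound 1 to compound 3 (0.27 log units; within the scatter) stays within the scatter, so methyl and methoxycarbonyl cannot be told apart there, just as methyl and isopropylcarbonyl could not; only the two acyl groups are separated from each other. Nothing measured alongside these numbers speaks to the origin of the step between isopropyl and methoxy.

Methoxy differs from isopropyl both in its heavy atoms and in carrying a hydrogen-bond acceptor, so the compounds shown do not say which of these differences goes with the step. From the compounds shown here alone, an ethyl, an ethoxy or a tert-butoxy on that carbonyl carbon would bear on this question, and whether any such group would separate from the methyl of compound 1 remains open.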